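Butyl quinolone series: acetyl to isopropylcarbamoyl on cytotoxicity

The compounds below may be only part of what the source reports. "The series", "measured", "known", "first", "only" and "open" are said of these compounds alone.

Compound 1 `CCCCc1cc2c(=O)c(C(C)=O)c[nH]c2cc1OCCOc1ccccc1` carries an acetyl on the shared core. In an ADME assay on J774 cells (Mus musculus) for cytotoxicity (on this read-out lower numbers stand for an effect already at smaller amounts and higher numbers for an effect only at larger amounts of compound), compound 1 stands at "not determined" (no result reported), so no number places it on the scale. Compound 2 `CCCCc1ccc2[nH]cc(C(=O)OC)c(=O)c2c1` shares the core without the phenoxyethoxy chain. In this assay compound 2 reaches only a limit of the assay, > 20000 nM. The one result shown is thus (the limit of > 20000 nM in this assay, at which 1 of the 2 values shown sits). Compound 3 `CCCCc1cc2c(=O)c(C(=O)NC(C)C)c[nH]c2cc1OCCOc1ccccc1` differs from compound 1 by isopropylamino in place of methyl on a carbonyl carbon. Going by the values given here, with no measured step between these compounds, the expectation for this assay is a change of at most the usual scatter, in no settled direction. Compound 3 is therefore estimated at 30000 nM, in the range 8000 nM to 120000 nM.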

Compound 3, half-maximal effective concentration: > 20000 nM
Compound 3 gave a limit, no number; the forecaster's own chance of this, stated with the estimate: 70%; the middle value lies beyond the limit too.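

In this assay compound 3 gives > 20000 nM, a limit and not a number. Going by these compounds alone, compound 1 has no number on this scale either, so no step between the two can be read. The compounds shown leave open whether acetyl to isopropylcarbamoyl shifts the read-out in this assay at all.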